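Fluorine Added to the Phenyl Ring of Compound 2

The source may hold more compounds than are shown below. What is called first, only, known or untested is meant among the compounds shown, and "the series" means these compounds.

Compound 1 `CC1(C)CC(=O)c2cc(C#N)c(NC3CCCC3)nc2C1` gives 78 nM in an in vitro functional assay on cells for antagonist activity at metabotropic glutamate receptor 1 (Rattus norvegicus), read by inositol phosphate accumulation; on this read-out higher numbers stand for weaker inhibition and lower numbers for stronger inhibition. Compound 2 `CC1(C)CC(=O)c2cc(C#N)c(N3CC=C(c4ccccc4)CC3)nc2C1` bears a different amine on the shared core. For compound 2 the assay reports only a limit, < 1000 nM, so where it truly stands is open; this is the limit of < 1000 nM in this assay, at which 1 of the 2 values shown sits. Compound 3 `CC1(C)CC(=O)c2cc(C#N)c(N3CC=C(c4ccc(F)cc4)CC3)nc2C1` differs from compound 2 by fluoro in place of hydrogen on an aromatic carbon. Within the data shown here, no measured pair shows what such a change does here, so the step in this assay is expected to be small, in either direction, within the usual scatter. Compound 3 is therefore estimated at 250 nM, ranging from 50 nM to 1200 nM, which means an expected step that the limit leaves unreadable from compound 2 to compound 3.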

Compound 3, half-maximal inhibitory concentration: 110 nM
The estimate for compound 3 lay 2.3-fold (0.36 log units) above the measured number, within the range that was stated.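

The step from compound 2 to compound 3 cannot be read in this assay, since compound 2 has only a limit and not a number: the limit of < 1000 nM in this assay, at which 1 of the 3 values shown sits.

Going by these compounds, what fluoro in place of hydrogen on the phenyl ring does to the inhibition in this assay stays open.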